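The source may hold more compounds than are shown below. What is called first, only, known or untested is meant among the compounds shown, and "the series" means these compounds.

Compound 1 `Clc1ccccc1COc1ccccc1/C=C/C(/C=C/c1ccccn1)=N/Oc1ncnc2ccccc12` is a quinazoline-linked oxime ether carrying a chlorobenzyl ether on one of its side chains. In a functional assay on SMMC-7721 cells (Homo sapiens) for inhibition, read by MTT assay, with a stated time of 72 h, tested at 1 uM (on this read-out lower numbers stand for a weaker effect and higher numbers for a stronger effect at the one concentration tested), compound 1 gives 95.7%. Two close relatives were measured alongside it. Compound 2 `Cc1cccc2ncnc(O/N=C(\C=C\c3ccccn3)/C=C/c3ccccc3OCc3ccccc3Cl)c12` gives 86.8%, and compound 3 `Clc1ccc2c(O/N=C(\C=C\c3ccccn3)/C=C/c3ccccc3OCc3ccccc3Cl)ncnc2c1` gives 94.8%. Compound 1 thus stands at the top of the three numbers shown, yet a number 8.9 percentage points lower from compound 1 to compound 2 (within the scatter) and a number 0.9 percentage points lower from compound 1 to compound 3 (within the scatter) are both within the scatter, so the three compounds cannot really be told apart.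

The next compound, compound 4 `Clc1ccc(COc2ccccc2/C=C/C(/C=C/c2ccccn2)=N/Oc2ncnc3ccccc23)c(Cl)c1`, differs from compound 1 in one place: chloro in place of hydrogen on an aromatic carbon.

For the measured compounds named here, the step that bears on this is the one to compound 3, which likewise brought in a chloro substituent where a hydrogen had been, though on the shared core rather than on the chlorobenzyl ether, and a number 0.9 percentage points lower from compound 1 to compound 3 (within the scatter) amounted to nothing beyond the scatter. The change to compound 2 on the core also stayed within the scatter. Going by the values given here, no measured pair touches the chlorobenzyl ring itself, so the evidence is indirect. On this basis compound 4 is expected to give 93%, with a range from 84% to 99%, which means a number 2.7 percentage points lower from compound 1 to compound 4 (within the scatter) is expected to stay within the scatter.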

Compound 4, a percentage reported as inhibition, at one concentration (the size of the read-out at that concentration, not a potency): 33.3%
For compound 4 the middle estimate is 59.7 percentage points above the measured one; the measured number lies below the stated range.
By their numbers in this assay, from the lowest: compound 4; then compounds 2, 3 and 1 (each within the scatter of the next).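

In this assay, the change from (2-chlorobenzyl)oxy to (2,4-dichlorobenzyl)oxy, which places a chloro meta to the existing chloro and para to a large group, gives a number 62.4 percentage points lower from compound 1 to compound 4 (beyond the scatter) and shows that this ring position tolerates the added atom poorly. The same kind of change made on the shared core, a number 0.9 percentage points lower from compound 1 to compound 3 (within the scatter), shows that swapping a hydrogen for a chloro is not harmful in itself in this series, and that its outcome differs between these two places on the molecule. Nothing shown here gives a measured reason for the size of the new step.

The compounds shown leave open whether the loss belongs to chloro in particular or to any group at this place on the ring, a question that a fluoro, a methyl or a methoxy group there could help to settle. Also open, as far as these compounds go, is what the existing chloro of compound 1 contributes, which a plain benzyl ether carrying no chlorine could begin to answer.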